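Series notes: dimethylamino for methoxy, compound 3 to compound 4

This account rests on a few compounds, and the source may have more. Where it says the series, first, only, none or still open, it means among the compounds named here.

Of the compounds shown here, three have been measured in a functional assay on HepG2 cells (Homo sapiens) for inhibition, read by MTT assay, with a stated time of 48 h; a lower number here means a stronger inhibitor, a higher number a weaker inhibitor. Compound 1 `COc1ccc(-n2c(SCc3ccc(C)cc3)nnc2-c2cc(OC)c(OC)c(OC)c2)cc1` gives 31600 nM. Compound 2 `COc1ccc(-n2c(SCC(=O)c3ccccc3)nnc2-c2cc(OC)c(OC)c(OC)c2)cc1` gives 16200 nM, and compound 3 `COc1ccc(-n2c(SCC(=O)c3ccc(F)cc3)nnc2-c2cc(OC)c(OC)c(OC)c2)cc1` gives 10700 nM, the lowest number shown, though its gap to compound 2 is within the scatter; the step of a 3.0-fold lower number from compound 1 to compound 3 (0.47 log units; beyond the scatter) is the only one beyond it. The other steps, a 2.0-fold lower number from compound 1 to compound 2 (0.29 log units; within the scatter) and a 1.5-fold lower number from compound 2 to compound 3 (0.18 log units; within the scatter), likewise concern the group on the saturated chain carbon bound to a sulfur.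

Compound 4 `COc1cc(-c2nnc(SCC(=O)c3ccc(F)cc3)n2-c2ccc(N(C)C)cc2)cc(OC)c1OC` keeps that part of compound 3 unchanged and differs on the other side: dimethylamino in place of methoxy on an aromatic carbon. Going by the values given here, no measured pair in the set alters this position; every step so far sits on the chain bound to sulfur, so nothing measured bears directly on the change. Without such a comparison, the working expectation is a step of a 1.1-fold lower number from compound 3 to compound 4 (0.03 log units; within the scatter) in this assay, that is, no change beyond the scatter. Compound 4 is estimated at 10000 nM, with a range from 3500 nM to 30000 nM, the width reflecting the absence of any precedent for this change within the series.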

Compound 4, half-maximal inhibitory concentration: > 60000 nM
Compound 4 gave a limit, no number; the forecaster's own chance of this, stated with the estimate: 5%; middle value at least 6.0-fold (0.77 log units) away from the limit.
By their numbers in this assay, from the lowest: compounds 3, 2 and 1 (each within the scatter of the next, the first and the last beyond it). At a limit, above all of these: compound 4.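

Going by these compounds alone, the 4-methoxyphenyl side of the core, held constant in the earlier compounds, responds strongly to change in this assay: dimethylamino in place of methoxy gives an at least 5.6-fold higher number from compound 3 to compound 4 (0.74 log units; beyond the scatter), a larger step than any seen on the chain bound to sulfur. Compound 4 gives > 60000 nM, which is a limit and not a number: the limit of > 60000 nM in this assay, at which 1 of the 4 values shown sits. On the background of compound 3, methoxy at this place therefore cannot be exchanged for dimethylamino without a step beyond the scatter, even though the counts of hydrogen-bond donors and acceptors are the same for the two groups.

A single pair cannot show which feature of dimethylamino goes with this step, or whether the same step would appear with the benzoyl of compound 2 or the 4-methylphenyl of compound 1 on the chain bound to sulfur. On these data alone, it also remains open whether methylamino, hydroxyl or ethoxy at this place would stay close to compound 3, and whether any group here would give a lower number than methoxy.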